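Chloro to Nitro at the Cytotoxicity Limit

A few compounds are considered here, and "the series" means these few. Any claim that something is new, unique, unknown or untested is made for them only; others in the source may bear on it.

Measured in an ADME assay on MDCK cells (Canis lupus familiaris) for cytotoxicity; on this read-out higher numbers stand for lower toxicity in this test and lower numbers for higher toxicity in this test:
- Compound 1 `CC(=O)Nc1ccc2oc(-c3ccnc(C(=O)N4CCC5(CC4)CCN(C(c4ccccc4)c4nnn(C)n4)CC5)c3)nc2c1`: > 50000 nM, a limit
- Compound 2 `CC(=O)Nc1ccc2oc(-c3ccnc(C(=O)N4CCN(C(c5ccc(Cl)cc5)c5nnn(C)n5)CC4)c3)nc2c1`: > 50000 nM, a limit

Compound 2 has no exact number and stands only at a limit of the assay. Compound 1 is in the same position, and the record so far reads: the limit of > 50000 nM in this assay, at which 2 of the 2 values shown sit.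

Compound 3 `CC(=O)Nc1ccc2oc(-c3ccnc(C(=O)N4CCN(C(c5ccc([N+](=O)[O-])cc5)c5nnn(C)n5)CC4)c3)nc2c1` keeps the frame of compound 2 but carries nitro in place of chloro on an aromatic carbon, para to a large group: nitro in place of chloro on an aromatic carbon. Among the compounds with values here, the change is 4-chlorophenyl to 4-nitrophenyl, and no measured pair differing in one place is available as a guide.

With compound 2 at > 50000 nM, a limit, no change beyond the scatter is expected in this assay. The expected size of the change is a number no higher from compound 2 to compound 3 (the limit leaves the size open). For compound 3 the estimated value is 50000 nM, with an expected range of 25000 nM to 100000 nM.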

Compound 3, half-maximal cytotoxic concentration: > 50000 nM
Compound 3 ended at the assay's limit; the forecaster's own chance of this, stated with the estimate: 80%; the middle value lies on the limit itself.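

Compound 2 and compound 3 both stand only at a limit in this assay, so no step can be read between them, and the record now reads: the limit of > 50000 nM in this assay, at which 3 of the 3 values shown sit.

The compounds shown leave open whether nitro in place of chloro changes this read-out at all, and in which direction.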